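A Shorter Link to the Dioxo-Oxazolidine Ring

The source may hold more compounds than are shown below. What is called first, only, known or untested is meant among the compounds shown, and "the series" means these compounds.

Measured compounds in a physicochemical assay for solubility, in phosphate buffer, measured as kinetic solubility (a lower number here means a less soluble compound, a higher number a more soluble compound), are these
compound 1 `CC(C)[C@@H](c1ccc(-c2ccc3cccc(F)c3c2)[nH]c1=O)[C@@H]1OC(=O)NC1=O` gives 27400 nM
compound 2 `CC(C)[C@H](C[C@H]1OC(=O)NC1=O)c1ccc(-c2ccc3cccc(F)c3c2)[nH]c1=O` gives 35400 nM
compound 3 `O=C1NC(=O)/C(=C/C(c2ccc(-c3ccc4cccc(F)c4c3)[nH]c2=O)C2CC2)O1` gives 30800 nM

Compound 2 stands at 35400 nM in this assay and lies within the scatter of both compound 1 and compound 3, so the three values do not separate. Compound 4 `CC(C)[C@@H](c1ccc(-c2ccc3cccc(F)c3c2)[nH]c1=O)[C@H]1OC(=O)NC1=O` has not yet been measured. It differs from compound 2 as follows 2,4-dioxo-1,3-oxazolidin-5-yl in place of (2,4-dioxo-1,3-oxazolidin-5-yl)methyl on a saturated chain carbon bound to an aromatic carbon and a saturated chain carbon and so carries 2,4-dioxo-1,3-oxazolidin-5-yl in place of (2,4-dioxo-1,3-oxazolidin-5-yl)methyl on a saturated chain carbon bound to an aromatic carbon and a saturated chain carbon. Within the data shown here, only one measured step bears on this exchange, and it runs in the opposite direction, namely a 1.3-fold higher number from compound 1 to compound 2 (0.11 log units; within the scatter) in that single case. A single small step is thin support, but it gives no reason to expect a real shift in this assay here. The expected step is a 1.2-fold lower number from compound 2 to compound 4 (0.09 log units; within the scatter) and thus none beyond the scatter. Compound 4 is therefore estimated at 29000 nM with an expected range from 15000 nM to 52000 nM in this assay when it is measured.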

Compound 4, solubility: 31600 nM
Compound 4: the middle estimate sits 1.1-fold (0.04 log units) below what was measured; the range from low to high includes it.
By their numbers in this assay, from the lowest: compounds 1, 3, 4 and 2 (each within the scatter of the next).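

With compound 4 in hand, this assay can be read for the shorter link on its own terms, with 2,4-dioxo-1,3-oxazolidin-5-yl in place of (2,4-dioxo-1,3-oxazolidin-5-yl)methyl, and the exchange gives a 1.1-fold lower number from compound 2 to compound 4 (0.05 log units; within the scatter). Among these compounds, the new pair also isolates the stereocentre at the saturated ring carbon, something no earlier pair could do, and inverting it as drawn gives a 1.2-fold higher number from compound 1 to compound 4 (0.06 log units; within the scatter). This second comparison tests configuration alone, with nothing else altered: the fact that compounds 1 and 4 differ only in the configuration as drawn

All four compounds carry the dioxo-oxazolidine ring, so they cannot show whether a carboxylic acid or an amine on this saturated chain carbon would give a step beyond the scatter in this assay. They also leave open how a longer chain to the ring would read there.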